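The compounds below may be only part of what the source reports. "The series", "measured", "known", "first", "only" and "open" are said of these compounds alone.

Measured compounds, all in an assay on isolated protein for inhibition of Amine oxidase [flavin-containing] B (Homo sapiens), read by fluorescence, with stated times of 15 min and 20 min; a higher number here means a weaker inhibitor, a lower number a stronger inhibitor:

- compound 1 `CC(C)(C)c1cc(CCC(=O)NCCC2CCN(Cc3ccccc3)CC2)cc(C(C)(C)C)c1O` gives 46900 nM
- compound 2 `CC(C)(C)c1cc(/C=C/C(=O)NCCC2CCN(Cc3ccccc3)CC2)cc(C(C)(C)C)c1O` gives 8500 nM
- compound 3 `CC(C)(C)c1cc(/C=C/C(=O)NCCC2CCN(Cc3ccccc3F)CC2)cc(C(C)(C)C)c1O` gives 7400 nM

On these numbers compound 2 stands close to compound 3, within the scatter, and well apart from compound 1, whose number is higher and beyond the scatter. Compound 4 `CC(C)(C)c1cc(/C=C/C(=O)NCCC2CCN(Cc3ccc(F)cc3F)CC2)cc(C(C)(C)C)c1O` has not been measured. It differs from compound 2 by 2,4-difluorophenyl in place of phenyl on a saturated chain carbon bound to an amine nitrogen in a ring. Among the compounds with values here, the one measured step that bears on this change is the addition of a single fluorine to the same ring, a 1.1-fold lower number from compound 2 to compound 3 (0.06 log units; within the scatter), which stayed within the scatter. A second fluorine on that ring is therefore expected to leave this assay reading largely unchanged, with no step beyond the scatter in either direction. Compound 4 is expected at 7000 nM, between 3500 nM and 14000 nM, a step of a 1.2-fold lower number from compound 2 to compound 4 (0.08 log units; within the scatter) that is expected to fall within the scatter.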

Compound 4, half-maximal inhibitory concentration: 12500 nM
Beside the measured number, compound 4's estimate is 1.8-fold (0.25 log units) below it; low and high end bracket the measured number.
By their numbers in this assay, from the lowest: compounds 3, 2 and 4 (each within the scatter of the next); then compound 1.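

Fluorine on this benzyl ring has so far left the number in this assay essentially unchanged. Going from phenyl to 2,4-difluorophenyl gives a 1.5-fold higher number from compound 2 to compound 4 (0.17 log units; within the scatter) and adding the further fluorine gives a 1.7-fold higher number from compound 3 to compound 4 (0.23 log units; within the scatter), so neither step separates these compounds. The position therefore accepts this change without a readable loss or gain. From the compounds shown here alone, whether a methoxy group, a nitrile or an amine on this ring would move the number beyond the scatter remains open. Nothing available explains why the fluorines make no readable difference.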